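The source may hold more compounds than are shown below. What is called first, only, known or untested is meant among the compounds shown, and "the series" means these compounds.

Compound 1 `CCOc1cc(CCc2nc(C)c(CC)s2)nc(NCc2cc(Cl)cc(NC(=O)OC(C)C)c2)c1` is one of three close relatives that share a core and differ only in the group attached through an oxygen on an aromatic ring. In an assay on cells for binding affinity to Neuropeptide Y receptor type 1 (Homo sapiens) (a lower number here means a stronger inhibitor, a higher number a weaker inhibitor), compound 1 gives 33 nM, the second highest of the three numbers. Compound 2 `CCc1sc(CCc2cc(OCC(C)(C)C)cc(NCc3cc(Cl)cc(NC(=O)OC(C)C)c3)n2)nc1C` gives 55 nM in this assay, and compound 3 `CCc1sc(CCc2cc(OC(CC)CC)cc(NCc3cc(Cl)cc(NC(=O)OC(C)C)c3)n2)nc1C` gives 5.5 nM. The step of a 1.7-fold higher number from compound 1 to compound 2 (0.22 log units; within the scatter) lies within the scatter, while the step of a 6.0-fold lower number from compound 1 to compound 3 (0.78 log units; beyond the scatter) and the step of a 10-fold lower number from compound 2 to compound 3 (1.00 log units; beyond the scatter) are both beyond it.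

Compound 4 `CCc1sc(CCc2cc(OCCCc3ccccc3)cc(NCc3cc(Cl)cc(NC(=O)OC(C)C)c3)n2)nc1C` has not yet been measured in this assay. It differs from compound 1 by the change (benzyl in place of hydrogen on a saturated chain carbon, two bonds along the chain from an oxygen on an aromatic ring). This lengthens the chain without branching it at the carbon bound to the oxygen, so it resembles the change from compound 1 to compound 2, which did nothing beyond the scatter, more than the branching change from compound 1 to compound 3. The expectation for compound 4 is therefore a step of a 1.2-fold lower number from compound 1 to compound 4 (0.07 log units; within the scatter), most likely small. Compound 4 is estimated at 28 nM, with a range from 9 nM to 90 nM.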

Compound 4, half-maximal inhibitory concentration: 20 nM
Compound 4: middle estimate off by 1.4-fold (0.15 log units), on the high side; measured number inside the range.
By their numbers in this assay, from the lowest: compound 3; then compounds 4, 1 and 2 (each within the scatter of the next, the first and the last beyond it).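

Replacing the ethoxy of compound 1 with 3-phenylpropoxy adds a full six-membered aromatic ring at this position, yet in this assay the step of a 1.7-fold lower number from compound 1 to compound 4 (0.22 log units; within the scatter) shows that this much larger group is tolerated. Compound 4 also separates from the neopentyl ether, with the step of a 2.8-fold lower number from compound 2 to compound 4 (0.44 log units; beyond the scatter) lying beyond the scatter, even though neither compound 2 nor compound 4 separates from compound 1. The pentan-3-yl group of compound 3 still gives the lowest number of the four, and the step of a 3.6-fold higher number from compound 3 to compound 4 (0.56 log units; beyond the scatter) shows that the phenyl-ended chain does not match it.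

Going by these compounds, it remains open how an amine or a carboxylic acid at the end of this chain, or a shorter benzyl group on the oxygen, would read in this assay here. Nothing shown explains these differences.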